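The source may hold more compounds than are shown below. What is called first, only, known or untested is meant among the compounds shown, and "the series" means these compounds.

Two compounds have been measured in a functional assay on U-373MG ATCC cells (Homo sapiens) for inhibition, read by MTT assay, with a stated time of 72 h; on this read-out lower numbers stand for stronger inhibition and higher numbers for weaker inhibition:

Compound 1 `O=[N+]([O-])c1ccc(NC(=S)NC2CCOc3ccc(Cl)cc32)cc1`: 8000 nM
Compound 2 `CC1(C)CC(NC(=S)Nc2ccc([N+](=O)[O-])cc2)c2cc(Cl)ccc2O1`: 3000 nM

Of these two, compound 2 has the lower number, and so the stronger inhibition; compound 1 returns a higher number, and the gap between them is larger than the usual scatter of repeated measurements. The two compounds differ in more than one place, so their values can only be compared as they stand, without tying the gap to any single change.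

Compound 3 `CC1(C)CC(NC(=S)Nc2ccc([N+](=O)[O-])cc2)c2cc(Br)ccc2O1` has not yet been measured. It differs from compound 2 in a single place: bromo in place of chloro on an aromatic carbon. Nothing in the measured pair shows how such a change affects the numbers, and swapping one halogen for another is generally a small change. In this assay the step is therefore expected to be small, with no clear direction, and most likely within the scatter. The expected step of a 1.1-fold lower number from compound 2 to compound 3 (0.03 log units; within the scatter) reflects this. Compound 3 is estimated at 2800 nM, within a range of 1000 nM to 8000 nM.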

Compound 3, half-maximal inhibitory concentration: 9000 nM
The estimate for compound 3 lay 3.2-fold (0.51 log units) below the measured number; measured number outside the range, above it.
By their numbers in this assay, from the lowest: compound 2; then compounds 1 and 3 (each within the scatter of the next).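

In this assay, the aromatic carbon that carries the halogen proves to matter: bromo in place of chloro gives a 3.0-fold higher number from compound 2 to compound 3 (0.48 log units; beyond the scatter) and therefore weaker inhibition. Going by these compounds alone, the earlier pair differed in more than one place, so this is the first gap that can be tied to a single change, and it shows that even swapping one halogen for another at this position is not a neutral move here. No supporting data explain why the step has this size and direction.

With only chloro and bromo at this position, a single step cannot show how fluoro, iodo, methoxy or a plain hydrogen would behave there. Also open, going by these compounds, is whether the same swap would give a similar step on the core of compound 1.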